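The source may hold more compounds than are shown below. What is called first, only, known or untested is meant among the compounds shown, and "the series" means these compounds.

Going by the values given here, in a functional assay on FM3A cells (Mus musculus) for inhibition, read by cell counting, with a stated time of 2 days (on this read-out higher numbers stand for weaker inhibition and lower numbers for stronger inhibition), compound 2 `C=C(Br)C(=O)Nc1cccc(-c2cn3nc(Cc4cccc(OC)c4)sc3n2)c1` gives 1100 nM, the only actual number in the set. Compound 1 `CCOc1ccc(-c2nn3cc(-c4cccc(N)c4)nc3s2)cc1` reaches only the assay limit, >= 250000 nM. Among the compounds with values here, the other value present is thus (the limit of >= 250000 nM in this assay, at which 1 of the 2 values shown sits), so no measured step between two compounds exists here. Compound 3 `C=C(Br)C(=O)Nc1cccc(-c2cn3nc(-c4ccccc4)sc3n2)c1` is to be measured in this assay; it differs from compound 2 by phenyl in place of 3-methoxybenzyl on an aromatic carbon. Within the data shown here, with no comparable step in hand, the expected step is modest, a 1.8-fold higher number from compound 2 to compound 3 (0.26 log units; within the scatter), toward weaker inhibition but near the scatter. Compound 3 is estimated at 2000 nM, within 600 nM to 7000 nM.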

Compound 3, half-maximal inhibitory concentration: 900 nM
Beside the measured number, compound 3's estimate is 2.2-fold (0.35 log units) above it; the range from low to high includes it.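

On the aromatic carbon of the five-membered aromatic ring, phenyl and 3-methoxybenzyl cannot be told apart in this assay (the step is a 1.2-fold lower number from compound 2 to compound 3 (0.09 log units; within the scatter)). At this position, activity in the low range of the series therefore does not depend on the 3-methoxybenzyl group: phenyl, with 6 heavy atoms and 0 hydrogen-bond acceptors, reads the same as the larger group. Nothing measured here bears on why the two groups read alike.

Going by these compounds, what an amine or a carboxylic acid on this carbon would do stays open. So does whether an unsubstituted benzyl group would read like these two.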